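The Step from Compound 3 to Compound 4

The source may report more compounds than this note shows. Statements on the series, on what has been measured and on what is new or still open speak of the compounds shown alone.

- Compound 1 `O=C(N/N=C/c1ccccc1)Nc1ccc(Oc2ccnc3[nH]ccc23)cc1`: 1510 nM
- Compound 2 `O=C(N/N=C/c1cccc(Cl)c1Cl)Nc1ccc(Oc2ccnc3[nH]ccc23)cc1`: "not active" (no number reported)
- Compound 3 `CN(C)CCn1cccc1/C=N/NC(=O)Nc1ccc(Oc2ccnc3[nH]ccc23)cc1`: "not determined" (no result reported)

Going by the values given here, in a functional assay on MCF7 cells (Homo sapiens) for antiproliferative activity, read by MTT assay, with a stated time of 72 h (on this read-out higher numbers stand for weaker inhibition and lower numbers for stronger inhibition), compound 1 gives the only number, 1510 nM, in this small set. Compound 3 has no single number to stand on, since its entry reads "not determined" (no result reported), and compound 2 likewise has none, reading "not active" (no number reported) as its result.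

Compound 4 `CN1CCN(CCCn2cccc2/C=N/NC(=O)Nc2ccc(Oc3ccnc4[nH]ccc34)cc2)CC1` has yet to be measured in this assay as well. Its structure departs from that of compound 3 by (4-methylpiperazin-1-yl)methyl in place of dimethylamino on a saturated chain carbon, two bonds along the chain from an aromatic nitrogen, which puts (4-methylpiperazin-1-yl)methyl in place of dimethylamino on a saturated chain carbon, two bonds along the chain from an aromatic nitrogen.

Among the compounds with values here, no measured step shows what such a change does, and compound 3 offers no value to step from, so no particular size or direction of step in this assay can be expected. Within the data shown here, the expectation therefore leans on compound 1 at 1510 nM as the sole number available. The estimated value for compound 4 is 1000 nM, with an expected range of 150 nM to 6000 nM, deliberately wide.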

Compound 4, half-maximal inhibitory concentration: 4280 nM
Compound 4: the middle estimate sits 4.3-fold (0.63 log units) below what was measured; the range from low to high includes it.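

In this assay, going by these compounds alone, compound 3 has no single number, so no step from compound 3 to compound 4 can be read. The compounds shown leave open what (4-methylpiperazin-1-yl)methyl in place of dimethylamino does on this read-out. No evidence bears on the value of compound 4.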